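Aryl Replacement on the Shared Core: Thiophene Variant

A few compounds are considered here, and "the series" means these few. Any claim that something is new, unique, unknown or untested is made for them only; others in the source may bear on it.

compound 1 `CCOC(=O)c1c(C)[nH]c(=O)c(C#N)c1-c1ccccc1`: > 100000 nM
compound 2 `CCOC(=O)c1c(C)[nH]c(=O)c(C#N)c1-c1ccc(C)cc1`: 15900 nM
compound 3 `CCOC(=O)c1c(C)[nH]c(=O)c(C#N)c1-c1ccc(Br)cc1`: > 100000 nM

In a functional assay on A549 cells (Homo sapiens) for inhibition, read by MTT assay, with a stated time of 24 h (on this read-out higher numbers stand for weaker inhibition and lower numbers for stronger inhibition), compound 1 gives > 100000 nM, which is a limit of the assay and not a number. Compound 2 gives 15900 nM. Compound 3 gives > 100000 nM, again a limit. Two of the three values sit at the limit of > 100000 nM in this assay, at which 2 of the 3 values shown sit. The step of an at least 6.2-fold lower number from compound 1 to compound 2 (0.79 log units; beyond the scatter) is the only one read in full; a step that the two limits leave unreadable from compound 1 to compound 3 cannot be sized, and an at least 6.2-fold higher number from compound 2 to compound 3 (0.79 log units; beyond the scatter) is read only as a bound. Compound 4 `CCOC(=O)c1c(C)[nH]c(=O)c(C#N)c1-c1cccs1` carries the change (thiophen-2-yl in place of phenyl on an aromatic carbon). Among the compounds with values here, no measured step exchanges the phenyl ring itself, so the measured steps give no direct guide. For compound 4 a number close to the limit is expected, 60000 nM within 10000 nM to 300000 nM. The step of an at least 1.6-fold lower number from compound 1 to compound 4 (0.22 log units; that floor lies within the scatter) is thus expected, with wide uncertainty.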

Compound 4, half-maximal inhibitory concentration: 20100 nM
The estimate for compound 4 lay 3.0-fold (0.47 log units) above the measured number; the measured number falls inside the stated range.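

In this assay, exchanging the phenyl ring itself registers at this position: thiophen-2-yl in place of phenyl gives an at least 4.9-fold lower number from compound 1 to compound 4 (0.69 log units; beyond the scatter) and thiophen-2-yl in place of 4-bromophenyl gives an at least 4.9-fold lower number from compound 3 to compound 4 (0.69 log units; beyond the scatter) as the second bound. Neither step has a full size, as compound 1 and compound 3 each stand at a limit of the assay: the limit of > 100000 nM in this assay, at which 2 of the 4 values shown sit. The step to the unsubstituted thiophene, a 1.3-fold higher number from compound 2 to compound 4 (0.10 log units; within the scatter), leaves compound 4 level with compound 2.

Open, as far as these compounds go, is whether a methyl group or an amine on the thiophene ring would shift this level, and whether furan-2-yl would match thiophen-2-yl.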